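A few compounds are considered here, and "the series" means these few. Any claim that something is new, unique, unknown or untested is made for them only; others in the source may bear on it.

Of the compounds shown here, three built on the same core have so far been tested in a functional assay on HCT-116 cells (Homo sapiens) for antiproliferative activity, read by sulforhodamine B assay, with a stated time of 72 h; a higher number here means a weaker inhibitor, a lower number a stronger inhibitor. Compound 1 `Cn1ncc(Cl)c1-c1cc(C(=O)N[C@@H]2CN[C@H](CCNS(C)(=O)=O)C[C@H]2c2ccc(F)c(F)c2)oc1Cl` gives 920 nM, compound 2 `Cn1ncc(Cl)c1-c1cc(C(=O)N[C@@H]2CN[C@H](CC(N)=O)C[C@H]2c2ccc(Cl)c(Cl)c2)oc1Cl` gives 650 nM, and compound 3 `Cn1ncc(Cl)c1-c1cc(C(=O)N[C@H]2CNCC[C@@H]2c2ccc(C(F)(F)F)cc2)oc1Cl` gives 1050 nM. Compound 2 shows the lowest of the three numbers, yet both other compounds lie within the usual scatter of it, so no order among them can be claimed. Compound 4 `Cn1ncc(Cl)c1-c1cc(C(=O)N[C@@H]2CN[C@H](CC(=O)NC3CCC3)C[C@H]2c2ccc(Cl)c(Cl)c2)oc1Cl` is still to be measured; it differs from compound 2 in one place: cyclobutyl in place of hydrogen on an amide-type nitrogen. The carbamoyl group thus becomes cyclobutylcarbamoyl. For the measured compounds named here, no step of this kind exists among the measured compounds, so the expected step of a 1.1-fold higher number from compound 2 to compound 4 (0.03 log units; within the scatter) is small and could fall either way. Compound 4 is therefore estimated at 700 nM in this assay, within a range from 300 nM to 1600 nM.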

Compound 4, half-maximal inhibitory concentration: 430 nM
Estimate against measurement, compound 4: 1.6-fold (0.21 log units) above, within the range that was stated.
By their numbers in this assay, from the lowest: compounds 4, 2, 1 and 3 (each within the scatter of the next, the first and the last beyond it).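

For the compounds shown here, this is the first step in which only one group differs, and it concerns the amide-type nitrogen: cyclobutyl in place of hydrogen gives a 1.5-fold lower number from compound 2 to compound 4 (0.18 log units; within the scatter) in this assay. Carbamoyl and cyclobutylcarbamoyl therefore cannot be told apart in this read-out, even with 4 more heavy atoms on that nitrogen. Nothing available offers an explanation for this result. From the compounds shown here alone, whether methyl or phenyl on the same nitrogen would also stay within the scatter remains open. So does the effect of replacing the whole amide with a carboxylic acid.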